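Swapping a pyrazole for a furan on the chloro-bearing ring

This account rests on a few compounds, and the source may have more. Where it says the series, first, only, none or still open, it means among the compounds named here.

Measured so far:
- Compound 1, `Cn1nc2c(=O)n(CC3(O)CCN(Cc4ccc(-c5ccco5)cc4Cl)CC3)cnc2c1-c1ccc(CNCCO)cc1`: 8.2 nM
- Compound 2, `CCNCc1ccc(-c2c3ncn(CC4(O)CCN(Cc5ccc(-c6ccco6)cc5Cl)CC4)c(=O)c3nn2C)cc1`: 15.2 nM
- Compound 3, `Cn1nc2c(=O)n(CC3(O)CCN(Cc4ccc(-n5cccn5)cc4Cl)CC3)cnc2c1-c1ccc(CN)cc1`: 233 nM

In an assay on isolated protein for inhibition of ubiquitin carboxyl-terminal hydrolase 7 (Homo sapiens), with stated times of 30 min and 2 h (a higher number here means a weaker inhibitor, a lower number a stronger inhibitor), compound 3 gives the highest number of the three, beyond the scatter from both compound 2 and compound 1, so it is the weakest inhibitor of this small set. Compound 4, `Cn1nc2c(=O)n(CC3(O)CCN(Cc4ccc(-c5ccco5)cc4Cl)CC3)cnc2c1-c1ccc(CN)cc1`, is compound 3 with one change: furan-2-yl in place of 1H-pyrazol-1-yl on an aromatic carbon. The resulting compound carries the same furan-2-yl group as compounds 1 and 2 and keeps the simple aminomethyl tail of compound 3.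

Within the data shown here, no measured pair isolates this pyrazole-to-furan exchange. Among the measured compounds shown here, the only measured step, a 1.9-fold higher number from compound 1 to compound 2 (0.27 log units; within the scatter), concerns the tail on the other end of the molecule and shows that tail edits there change little. Compounds 1 and 2, both bearing furan-2-yl, sit far below compound 3, which suggests much of compound 3's weakness may go with the pyrazole, though the tail also differs between them.

Compound 4 is therefore expected to move strongly toward compounds 1 and 2, with the step of a 7.8-fold lower number from compound 3 to compound 4 (0.89 log units; beyond the scatter), giving an estimated 30 nM (range 10 nM to 100 nM).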

Compound 4, half-maximal inhibitory concentration: 18.1 nM
The estimate for compound 4 lay 1.7-fold (0.22 log units) above the measured number, within the range that was stated.
By their numbers in this assay, from the lowest: compounds 1, 2 and 4 (each within the scatter of the next, the first and the last beyond it); then compound 3.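

In this assay the exchange of 1H-pyrazol-1-yl for furan-2-yl alone brings a 13-fold lower number from compound 3 to compound 4 (1.11 log units; beyond the scatter) with the aminomethyl tail unchanged, so the ring at this place, meta to the chloro group, has a large effect on the number. With furan-2-yl in place, edits on the amine nitrogen count for far less: hydrogen in place of ethyl gives a 1.2-fold higher number from compound 2 to compound 4 (0.08 log units; within the scatter) and hydrogen in place of 2-hydroxyethyl gives a 2.2-fold higher number from compound 1 to compound 4 (0.34 log units; beyond the scatter) as a modest step. No measurement here explains why the furan-2-yl compound gives the much lower number.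

The compounds shown leave open whether the furan oxygen matters, which a thiophene-2-yl or phenyl group at this place could test. They also leave open whether a 1H-pyrazol-4-yl group, joined through carbon, would behave like the furan-2-yl group or the 1H-pyrazol-1-yl group.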